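The source may report more compounds than this note shows. Statements on the series, on what has been measured and on what is new or still open speak of the compounds shown alone.

Measured in an ADME assay (liver) for metabolic stability, with Liver microsome (Homo sapiens) as the target, using microsomes and NADPH, with a stated time of 30 min, tested at 1 uM; a higher number here means faster removal of the compound, a lower number slower removal:
- compound 1 `Nc1ccc(S(=O)(=O)N2CCN(c3ncc(C(O)(C(F)(F)F)C(F)(F)F)cc3C#CC3CC3)CC2)cn1` gives < 14 mL.min-1.g-1, which is a limit of the assay and not a number.
- compound 2 `CC(C)(O)C#Cc1cc(C(O)(C(F)(F)F)C(F)(F)F)cnc1N1CCN(S(=O)(=O)c2ccc(N)nc2)CC1` gives < 14 mL.min-1.g-1, again a limit of the assay.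
- compound 3 `Nc1ccc(S(=O)(=O)N2CCN(c3ncc(C(O)(C(F)(F)F)C(F)(F)F)cc3-c3ccc4ocnc4c3)CC2)cn1` gives < 14 mL.min-1.g-1, also a limit of the assay.

Compound 2 therefore stands at the limit, and so do the two other measured compounds: the limit of < 14 mL.min-1.g-1 in this assay, at which 3 of the 3 values shown sit. No number separates any of the three.

Compound 4 `Cc1nc2cc(-c3cc(C(O)(C(F)(F)F)C(F)(F)F)cnc3N3CCN(S(=O)(=O)c4ccc(N)nc4)CC3)ccc2o1` is the next compound to be measured. It differs from compound 2 in one place: 2-methyl-1,3-benzoxazol-5-yl in place of 3-hydroxy-3-methylbut-1-yn-1-yl on an aromatic carbon

The measured steps that bear on this change are the two that bring in 1,3-benzoxazol-5-yl, a step that the two limits leave unreadable from compound 2 to compound 3 and a step that the two limits leave unreadable from compound 1 to compound 3, together with a step that the two limits leave unreadable from compound 1 to compound 2. None of them has a readable size, since every value involved is a limit, so they give no direction and no size of step beyond the scatter.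

The expectation is that compound 4 remains at the limit, with an estimated step that the limit leaves unreadable from compound 2 to compound 4. The estimate for compound 4 in this assay is 10 mL.min-1.g-1, expected between 4 mL.min-1.g-1 and 25 mL.min-1.g-1.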

Compound 4, intrinsic clearance in microsomes: < 14 mL.min-1.g-1
Compound 4 ended at the assay's limit; the forecaster's own chance of this, stated with the estimate: 70%; the middle value does not contradict the limit.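

Compound 4 gives only a limit of the assay in this assay, just as compound 1, compound 2 and compound 3 do, so no step to compound 4 can be read: the limit of < 14 mL.min-1.g-1 in this assay, at which 4 of the 4 values shown sit.

The compounds shown leave open whether any of these group changes on the shared core alters the speed of removal at all.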